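The source may hold more compounds than are shown below. What is called first, only, known or untested is meant among the compounds shown, and "the series" means these compounds.

compound 1 `O=C(Nc1ccc(-c2cscn2)cc1)C1CCCN(Cc2ccccc2F)C1`: 4000 nM
compound 2 `O=C(Nc1ccc(-c2cscn2)cc1)C1CCCN(Cc2cccc(F)c2)C1`: 2450 nM
compound 3 `O=C(Nc1ccc(-c2cscn2)cc1)C1CCCN(Cc2ccc(Cl)c(Cl)c2)C1`: 1730 nM

All three values come from a functional assay on A-375 cells (Homo sapiens) for antiproliferative activity; a lower number here means a stronger inhibitor, a higher number a weaker inhibitor. Compound 3 cannot be separated from its nearest neighbour, as shown by a 1.4-fold lower number from compound 2 to compound 3 (0.15 log units; within the scatter). It is separated only from the furthest compound, as shown by a 2.3-fold lower number from compound 1 to compound 3 (0.36 log units; beyond the scatter).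

Next in the series is compound 4 `O=C(Nc1ccc(-c2cscn2)cc1)C1CCCN(Cc2ccc3cn[nH]c3c2)C1`, with this change: 1H-indazol-6-yl in place of 3,4-dichlorophenyl on a saturated chain carbon bound to an amine nitrogen in a ring. In other words, 3,4-dichlorobenzyl gives way to (1H-indazol-6-yl)methyl.

Three measured steps fall at this same place: a 1.6-fold lower number from compound 1 to compound 2 (0.21 log units; within the scatter), a 2.3-fold lower number from compound 1 to compound 3 (0.36 log units; beyond the scatter) and a 1.4-fold lower number from compound 2 to compound 3 (0.15 log units; within the scatter). Only the second goes beyond the scatter, and only modestly. Going by the values given here, no measured compound carries 1H-indazol-6-yl, so these steps indicate a likely size but give no firm direction. The data therefore support no expected shift beyond the scatter in this assay, with a slight lean towards a higher number. The expected change is a 1.4-fold higher number from compound 3 to compound 4 (0.16 log units; within the scatter). The estimate for compound 4 is 2500 nM, with an expected range of 900 nM to 7000 nM.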

Compound 4, half-maximal inhibitory concentration: > 20000 nM
Compound 4: only a limit was reported; the forecaster's own chance of this, stated with the estimate: 8%; at least 8.0-fold (0.90 log units) between middle value and limit.
By their numbers in this assay, from the lowest: compounds 3, 2 and 1 (each within the scatter of the next, the first and the last beyond it). At a limit, above all of these: compound 4.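

In this assay compound 4 is reported only as a limit: the limit of > 20000 nM in this assay, at which 1 of the 4 values shown sits. Even so, this place on the saturated chain carbon bound to the ring amine nitrogen proves far less forgiving than the fluorophenyl and dichlorophenyl groups suggested, with an at least 11-fold higher number from compound 3 to compound 4 (1.06 log units; beyond the scatter), an at least 8.1-fold higher number from compound 2 to compound 4 (0.91 log units; beyond the scatter) and an at least 5.0-fold higher number from compound 1 to compound 4 (0.69 log units; beyond the scatter). Going by these compounds alone, the change brings in a five-membered aromatic ring with 2 hetero atoms, 1 hydrogen-bond donor and 1 hydrogen-bond acceptor, and the single compound cannot say which of these goes with the higher number.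

A naphthyl or a 1-methylindazol-6-yl group at this place would help to separate the fused ring from the ring nitrogen-hydrogen. As far as these compounds go, how far compound 4 lies past its limit stays unknown, and a pyridin-3-yl ring would test whether a single ring nitrogen already raises the number.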